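The source may report more compounds than this note shows. Statements on the series, on what has been measured and on what is new or still open speak of the compounds shown alone.

Measured so far:
Compound 1 `COc1ccc(/C=C/C(=O)/C=C/c2cc3ccccc3nc2Cl)c(OC)c1`: > 10000 nM
Compound 2 `COc1ccc(/C=C/C(=O)/C=C/c2cc3ccccc3nc2Oc2ccccc2)cc1`: > 10000 nM

Both readings come from a functional assay on PC-3 cells (Homo sapiens) for cytotoxicity, read by MTT assay, with a stated time of 48 h (on this read-out lower numbers stand for stronger inhibition and higher numbers for weaker inhibition), and the overall picture is the limit of > 10000 nM in this assay, at which 2 of the 2 values shown sit. Among the measured compounds shown here, compound 2 gives > 10000 nM, which is a limit and not a number, and it is the only reading for that compound.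

Compound 3 `COc1ccc(/C=C/C(=O)/C=C/c2cc3ccccc3nc2Oc2ccccc2)c(OC)c1` differs from compound 2 by one change: methoxy in place of hydrogen on an aromatic carbon. This is methoxy in place of hydrogen on an aromatic carbon, taking 4-methoxyphenyl to 2,4-dimethoxyphenyl.

For the measured compounds named here, no measured step gives a size for this change. In this assay the expectation is therefore no move beyond the scatter, with a further limit reading the likeliest outcome. The expected step is a number no higher from compound 2 to compound 3 (the limit leaves the size open). For compound 3 the estimated value is 10000 nM, with an expected range of 3000 nM to 30000 nM.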

Compound 3, half-maximal inhibitory concentration: > 10000 nM
Compound 3: a limit, no number (the forecaster's own chance of this, stated with the estimate: 65%); the middle value lies on the limit itself.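

In this assay compound 3 gives > 10000 nM, a limit and not a number, so the steps to it from compound 1 and compound 2 cannot be read. Whether the methoxy or the phenoxy change moves the value at all stays open, and the overall picture is still: the limit of > 10000 nM in this assay, at which 3 of the 3 values shown sit.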